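The source may hold more compounds than are shown below. What is called first, only, known or untested is meant among the compounds shown, and "the series" means these compounds.

The series shares one fused core with a single variable substituent. Compound 1 `c1ccc(CNc2[nH]ccc3ncnc2-3)cc1` carries a benzylamino group; in a functional assay on the whole organism (Pleural cavity) with Rattus norvegicus as the target (on this read-out lower numbers stand for an effect already at smaller amounts and higher numbers for an effect only at larger amounts of compound), compound 1 gives 9 mg/kg. Compound 2 `Clc1[nH]ccc2ncnc1-2` carries a chloro in the same place. In this assay compound 2 reaches only > 9 mg/kg, which is a limit of the assay and not a number. For the measured compounds named here, compound 2 therefore stands at the limit of > 9 mg/kg in this assay, at which 1 of the 2 values shown sits, and no measured step between two numbers exists in this set. Compound 3 `Nc1[nH]ccc2ncnc1-2` is the next member. Its structural change from compound 2 is amino in place of chloro on an aromatic carbon. Going by the values given here, for this change no step has been measured. The expected step that the limit leaves unreadable from compound 2 to compound 3 is estimated as small, not beyond the scatter, with the direction uncertain. Compound 3 is estimated at 15 mg/kg, within a range from 5 mg/kg to 50 mg/kg, and with a fair chance that this assay again reports only a limit.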

Compound 3, dose for half-maximal effect: 8 mg/kg
Beside the measured number, compound 3's estimate is 1.9-fold (0.27 log units) above it; the range from low to high includes it.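

In this assay, compound 1 gives 9 mg/kg and compound 3 gives 8 mg/kg, two values that lie within the usual scatter of each other, so the plain amino group at this position reads the same as the benzylamino group and the benzyl part shows no visible contribution. The change of chloro to amino is recorded as an at least 1.1-fold lower number from compound 2 to compound 3 (0.05 log units; that floor lies within the scatter), which gives a floor and not a size. Only a floor can be given because compound 2 holds a limit of the assay and not a number: the limit of > 9 mg/kg in this assay, at which 1 of the 3 values shown sits.

Going by these compounds, how far the chloro compound truly stands from the amino compound remains open. Also open, on these data alone, is whether methylamino, a longer alkylamino chain or methoxy at this position would keep a readable value in this assay.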